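The source may hold more compounds than are shown below. What is called first, only, known or untested is meant among the compounds shown, and "the series" means these compounds.

Within the data shown here, in a functional assay on MKN-45 cells (Homo sapiens) for inhibition, with a stated time of 72 h (on this read-out lower numbers stand for stronger inhibition and higher numbers for weaker inhibition), compound 2 `COc1ccc(S(=O)(=O)N2CCc3cccc(-c4ccc([N+](=O)[O-])cc4)c32)cc1` gives 34 nM, the lowest of the three numbers measured so far. Compound 1 `COc1ccc(S(=O)(=O)N2CCc3cccc(-c4ccc(F)nc4)c32)cc1` gives 145 nM, and compound 3 `COc1ccc(S(=O)(=O)N2CCc3cccc(-c4cc(OC)c(OC)c(OC)c4)c32)cc1` gives 1080 nM. Compound 4 `COc1ccc(S(=O)(=O)N2CCc3cccc(-c4ccc(F)cc4)c32)cc1` differs from compound 2 by fluoro in place of nitro on an aromatic carbon. Among the measured compounds shown here, the only measured step that bears on this change is a 4.3-fold lower number from compound 1 to compound 2 (0.63 log units; beyond the scatter), in which the compound carrying the nitro group gave the lower number. For the measured compounds named here, no measured pair shows fluoro in place of nitro directly, so the expectation rests on that single step: taking the nitro group away is expected to move the number upward again in this assay. Compound 4 is therefore expected to give 130 nM, with a range from 45 nM to 400 nM, which would mean a 3.8-fold higher number from compound 2 to compound 4 (0.58 log units; beyond the scatter).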

Compound 4, half-maximal inhibitory concentration: 79 nM
For compound 4 the middle estimate is 1.6-fold (0.22 log units) above the measured one; the measured number falls inside the stated range.
By their numbers in this assay, from the lowest: compound 2; then compounds 4 and 1 (each within the scatter of the next); then compound 3.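

In this assay the nitro group proves not to be essential for a low number, although the step from nitro to fluoro on the same phenyl ring, a 2.3-fold higher number from compound 2 to compound 4 (0.37 log units; beyond the scatter), does lie beyond the scatter. The 4-fluorophenyl and 6-fluoropyridin-3-yl groups cannot be told apart, with a 1.8-fold lower number from compound 1 to compound 4 (0.26 log units; within the scatter), so that comparison shows no separation between these two rings.

Nothing measured here explains the gap between nitro and fluoro. On these data alone, whether an amine or a carboxylic acid at this position would sit nearer compound 2 or compound 3 remains open.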